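Second chloro on the anilide of compound 3

This account rests on a few compounds, and the source may have more. Where it says the series, first, only, none or still open, it means among the compounds named here.

Of the compounds shown here, three of the shared core have been measured in a functional assay on MGC-803 cells (Homo sapiens) for inhibition, read by MTT assay, with a stated time of 72 h; a higher number here means a weaker inhibitor, a lower number a stronger inhibitor. Compound 1 `O=C(CSc1nc(Nc2ccccc2)c2ccccc2n1)Nc1ccccc1F` gives 10700 nM. Compound 2 `O=C(CSc1nc(Nc2ccccc2)c2ccccc2n1)Nc1cccc(F)c1` gives 12700 nM. Compound 3 `O=C(CSc1nc(Nc2ccccc2)c2ccccc2n1)Nc1ccc(Cl)cc1` gives 40400 nM, the highest number of the three, by a 3.2-fold higher number from compound 2 to compound 3 (0.50 log units; beyond the scatter) and by a 3.8-fold higher number from compound 1 to compound 3 (0.58 log units; beyond the scatter), both beyond the scatter, whereas a 1.2-fold higher number from compound 1 to compound 2 (0.07 log units; within the scatter) stays within it.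

Compound 4 `O=C(CSc1nc(Nc2ccccc2)c2ccccc2n1)Nc1ccc(Cl)cc1Cl` is not yet measured. It differs from compound 3 by chloro in place of hydrogen on an aromatic carbon; the added chloro sits on an aromatic carbon of a six-membered aromatic ring of carbon only, ortho to a large group and meta to a chloro group.

Going by the values given here, no measured step adds a second halogen to an aryl that already carries one, so the step from compound 3 to compound 4 has no direct precedent. The steps of a 3.8-fold higher number from compound 1 to compound 3 (0.58 log units; beyond the scatter) and a 3.2-fold higher number from compound 2 to compound 3 (0.50 log units; beyond the scatter) show only that the 4-chlorophenyl amide reads higher than either fluorophenyl amide, and a 1.2-fold higher number from compound 1 to compound 2 (0.07 log units; within the scatter) shows that moving a single fluoro changes little. The step of a 1.1-fold higher number from compound 3 to compound 4 (0.05 log units; within the scatter) is therefore expected to be small, if anything toward a higher number. Compound 4 is estimated at 45000 nM in this assay, with a range of 15000 nM to 130000 nM.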

Compound 4, half-maximal inhibitory concentration: 12300 nM
Beside the measured number, compound 4's estimate is 3.7-fold (0.56 log units) above it; the measured number lies below the stated range.
By their numbers in this assay, from the lowest: compounds 1, 4 and 2 (each within the scatter of the next); then compound 3.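

In this assay the added chloro on an aromatic carbon, ortho to a large group and meta to a chloro group, gives a 3.3-fold lower number from compound 3 to compound 4 (0.52 log units; beyond the scatter) and shows that this position on the anilide responds to substitution, and that a second halogen on an aryl already carrying one need not raise the number. The 2,4-dichlorophenyl amide reads level with both fluorophenyl amides, by a 1.0-fold lower number from compound 2 to compound 4 (0.01 log units; within the scatter) and by a 1.1-fold higher number from compound 1 to compound 4 (0.06 log units; within the scatter) so the high number of compound 3 does not extend to every chloro-bearing aryl, and among these four compounds only the 4-chlorophenyl amide stands apart. No measurement at hand bears on what lies behind this change.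

Going by these compounds, whether a methoxy, a nitrile or a carboxylic acid in place of the added chloro would read like the chloro remains open. Also open, on these data alone, is how an amine or a longer chain elsewhere on the shared core would affect the number in this assay and whether the chloro step would hold on such a compound.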